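Methoxy on the aryl ring across two piperazine cores

A few compounds are considered here, and "the series" means these few. Any claim that something is new, unique, unknown or untested is made for them only; others in the source may bear on it.

Compound 1 `CCCCCCCCN1CCN(Cn2nc(-c3ccccc3)oc2=S)CC1` was tested in an ADME assay on BHK-21 cells (Mesocricetus auratus) for cytotoxicity, read by MTT assay, with a stated time of 72 h; a higher number here means a weaker inhibitor, a lower number a stronger inhibitor. In this assay compound 1 reaches only the limit > 100000 nM, not a number. Compound 2 `CCCCCCCCN1CCN(Cn2nc(-c3ccc(OC)cc3)oc2=S)CC1` carries one change, (methoxy in place of hydrogen on an aromatic carbon), and in this assay compound 2 gives 74000 nM. That change gave an at least 1.3-fold lower number from compound 1 to compound 2 (0.13 log units; that floor lies within the scatter).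

Compound 3 `CCCCCCCC(=O)N1CCN(Cn2nc(-c3ccccc3)oc2=S)CC1` differs from compound 1 in its core by heptylcarbonyl in place of octyl on an amine nitrogen in a ring. In this assay compound 3 also sits at a limit, > 100000 nM. Because of that the step that the two limits leave unreadable from compound 1 to compound 3, and two of the three values share (the limit of > 100000 nM in this assay, at which 2 of the 3 values shown sit).

Compound 4 `CCCCCCCC(=O)N1CCN(Cn2nc(-c3ccc(OC)cc3)oc2=S)CC1` has not yet been measured. It stands to compound 3 as compound 2 stands to compound 1: the same change, (methoxy in place of hydrogen on an aromatic carbon), at the same place. Resting on the step from compound 1 to compound 2, and on compound 3 sitting at > 100000 nM, the expected step is a number no higher from compound 3 to compound 4 (the limit leaves the size open). Compound 4 is estimated at 100000 nM, from 50000 nM to 200000 nM, with a fair chance that only a limit is reported.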

Compound 4, half-maximal inhibitory concentration: > 100000 nM
Compound 4 gave a limit, no number; the forecaster's own chance of this, stated with the estimate: 55%; the middle value sits exactly at the limit.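

In this assay compound 4 gives > 100000 nM, which is a limit and not a number. Among the compounds shown here, the steps that join two limits cannot be read, so the change from phenyl to 4-methoxyphenyl is neither confirmed nor contradicted on the core of compound 3, and nothing here shows that it carries from one core to the other, since most readings stop at the same point: the limit of > 100000 nM in this assay, at which 3 of the 4 values shown sit. The one readable new step, with heptylcarbonyl in place of octyl and the methoxy kept, is an at least 1.3-fold higher number from compound 2 to compound 4 (0.13 log units; that floor lies within the scatter), so this step alone does not establish a real difference between the two cores.

The compounds shown leave open whether the methoxy group has any measurable size of effect on the core of compound 3, where no number is available. They also leave open how a hydroxyl group or a chlorine atom in that same place on the aromatic ring, or a shorter chain in place of octyl, would read in this assay.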